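Taking one fluoro group off compound 3

The source may report more compounds than this note shows. Statements on the series, on what has been measured and on what is new or still open speak of the compounds shown alone.

compound 1 `Cc1cc(NC(=O)Nc2ccccc2N)c2ccccc2n1`: > 25000 nM (a limit, not a number)
compound 2 `Cc1ccc(NC(=O)Nc2cc(C)nc3ccccc23)cc1`: > 25000 nM (a limit, not a number)
compound 3 `Cc1cc(NC(=O)Nc2ccc(F)cc2F)c2ccccc2n1`: 20000 nM

Within the data shown here, in an ADME assay on BJ cells (Homo sapiens) for cytotoxicity, with a stated time of 72 h (on this read-out lower numbers stand for an effect already at smaller amounts and higher numbers for an effect only at larger amounts of compound), compound 3 gives 20000 nM, the only true number among the three. Compound 1 and compound 2 each stand at a limit of the assay. The picture is therefore dominated by the limit of > 25000 nM in this assay, at which 2 of the 3 values shown sit.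

Compound 4 `Cc1cc(NC(=O)Nc2ccccc2F)c2ccccc2n1` has not yet been measured. It differs from compound 3 by a single change, hydrogen in place of fluoro on an aromatic carbon.

Among the measured compounds shown here, the only measured step is a step that the two limits leave unreadable from compound 1 to compound 2. That step involves no fluoro group and has no readable size, so it offers no size to carry over. With so little to go on, only a small change is expected, and a reading at the limit would be no surprise. The expected change is a 1.2-fold higher number from compound 3 to compound 4 (0.08 log units; within the scatter). For compound 4 the estimate is 24000 nM, with an expected range from 13000 nM to 40000 nM.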

Compound 4, half-maximal effective concentration: > 25000 nM
Compound 4: no number, only a limit (the forecaster's own chance of this, stated with the estimate: 60%); middle value at least 1.0-fold (0.01 log units) from the limit.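

In this assay, compound 4 reaches only a limit of the assay, not a number, so the step of an at least 1.2-fold higher number from compound 3 to compound 4 (0.09 log units; that floor lies within the scatter) has a floor but no upper end. Since that floor lies within the scatter, the result does not show that hydrogen in place of fluoro at this position, meta to a fluoro group and para to a large group, changes the read-out at all. The other new steps join two limits and cannot be read, and the series now rests almost entirely on a single ceiling: the limit of > 25000 nM in this assay, at which 3 of the 4 values shown sit.

From the compounds shown here alone, how far compound 4 lies past its limit stays open. Also open, going by these compounds, is whether a chloro or methoxy group in this same place would give a true number in this assay.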